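This account rests on a few compounds, and the source may have more. Where it says the series, first, only, none or still open, it means among the compounds named here.

Working notes on the series, read in a toxicity assay on HEK-293T cells (Homo sapiens) for cytotoxicity, read by MTT assay, with a stated time of 72 h; a higher number here means a weaker inhibitor, a lower number a stronger inhibitor. Compound 1 (`O=C(N/N=C/C1=Cc2ccccc2OC1)c1ccc(Cl)cc1`) has no number to work with: its entry reads "not determined" (no result reported). Among the measured compounds shown here, compound 2 (`O=C(N/N=C/C1=Cc2ccccc2OC1c1ccccc1)c1ccc(Cl)cc1`) gives 13200 nM, the only number available so far, so it cannot yet be ranked against any other compound.

Compound 3 (`O=C(N/N=C/C1=Cc2ccccc2OC1c1ccccc1)c1ccc(F)cc1`) keeps the core of compound 2 and differs in one place: fluoro in place of chloro on an aromatic carbon. This is fluoro in place of chloro on an aromatic carbon, para to a large group, turning 4-chlorophenyl into 4-fluorophenyl.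

For the measured compounds named here, no measured pair shows this exchange or any other, so the data give no direct guide to its size. The expectation therefore rests on compound 2 at 13200 nM and on the small extent of the structural change. No step beyond the usual scatter is expected, and no firm direction can be assigned. The expected change is a 1.1-fold higher number from compound 2 to compound 3 (0.06 log units; within the scatter). For compound 3 the estimated value is 15000 nM, with an expected range from 7000 nM to 32000 nM.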

Compound 3, half-maximal inhibitory concentration: 30900 nM
Beside the measured number, compound 3's estimate is 2.1-fold (0.31 log units) below it, within the range that was stated.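

Replacing 4-chlorophenyl with 4-fluorophenyl gives the series its first readable step in this assay (a 2.3-fold higher number from compound 2 to compound 3 (0.37 log units; beyond the scatter)), and the direction is towards weaker inhibition. Among the compounds shown here, this position on the aromatic ring, para to a large group, is therefore not indifferent to the exchange of chloro for fluoro, even though only one heavy atom changes and neither group counts any hydrogen-bond donor or acceptor. The step is modest and rests on a single pair, and no measurement available here bears on its cause.

Only chloro and fluoro are shown at this position, so it remains open whether an amine, a methoxy group or a carboxylic acid in the same place would move the number further, leave it unchanged or reverse the direction seen with this pair. The step from compound 1 to compound 2 cannot be read, which leaves the contribution of the phenyl group on the shared core unknown, and with it any comparison of that change with the exchange at the 4-chlorophenyl group.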